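Adding Trifluoromethyl to a Well-Tolerated Compound

The source may hold more compounds than are shown below. What is called first, only, known or untested is meant among the compounds shown, and "the series" means these compounds.

Among the measured compounds shown here, compound 3 `C/C(=N\NC(N)=S)c1ccc2[nH]c(-c3ccccc3)nc2c1` is the only compound here with a reading in an ADME assay on MT4 cells (Homo sapiens) for cytotoxicity, read by MTT assay, with a stated time of 96 h; a lower number here means that less compound is tolerated, a higher number that more compound is tolerated. In this assay compound 3 gives >= 100000 nM, which is a limit of the assay and not an exact number. Two relatives add no reading: compound 1 `CC(=O)c1ccc2[nH]c(-c3ccc(C(F)(F)F)cc3)nc2c1` gives "not determined" (no result reported), and compound 2 `C/C(=N\NC(N)=O)c1ccc2[nH]c(-c3ccc(C(F)(F)F)cc3)nc2c1` gives "not determined" (no result reported).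

Compound 4 `C/C(=N\NC(N)=S)c1ccc2[nH]c(-c3ccc(C(F)(F)F)cc3)nc2c1` differs from compound 3 in one place: trifluoromethyl in place of hydrogen on an aromatic carbon. This puts trifluoromethyl in place of hydrogen on an aromatic carbon. For the measured compounds named here, no measured pair shows what this change does in this assay, so any expectation is rough. With compound 3 at >= 100000 nM, a number for compound 4 could only fall on the lower side, meaning less compound tolerated, and another limit reading remains quite possible. A moderate step is expected, beyond the usual scatter, and the estimated move is an at least 2.8-fold lower number from compound 3 to compound 4 (0.45 log units; beyond the scatter). The estimate for compound 4 is 35000 nM, with an expected range of 7000 nM to 100000 nM.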

Compound 4, half-maximal cytotoxic concentration: 2000 nM
Compound 4: middle estimate off by 18-fold (1.24 log units), on the high side, outside the stated range (below it).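

Placing trifluoromethyl on an aromatic carbon of this six-membered aromatic ring of carbon only, para to a large group, has a large effect in this assay, giving an at least 50-fold lower number from compound 3 to compound 4 (1.69 log units; beyond the scatter). Among the compounds shown here, this is the first pair here to show the change at work, and it shows that this single swap is enough to turn a well-tolerated compound into a much less tolerated one. The step can be given only as a minimum because compound 3 stands at a limit of the assay: the limit of >= 100000 nM in this assay, at which 1 of the 4 values shown sits.

Going by these compounds, it remains open whether this fall in tolerance is particular to trifluoromethyl or would also follow from another group in the same place, such as a chlorine atom, a methoxy group or an amine. On these data alone, it is also open whether a smaller group, such as methyl, would give a step of similar size.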